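The source may report more compounds than this note shows. Statements on the series, on what has been measured and on what is new or still open speak of the compounds shown alone.

Measured compounds:
compound 1, `COC(=O)c1nc(C(C)C)n(-c2ccc(F)cc2)n1` — > 100000 nM
compound 2, `COC(=O)c1nc(C2CCCC2)n(-c2ccc(F)cc2)n1` — 9550 nM

In a functional assay on Jurkat cells (Homo sapiens) for inhibition, read by MTT assay, with a stated time of 72 h (a lower number here means a stronger inhibitor of growth, a higher number a weaker inhibitor of growth), compound 1 gives > 100000 nM, which is a limit of the assay and not a number. Compound 2 in this assay gives 9550 nM. The step of an at least 10-fold lower number from compound 1 to compound 2 (1.01 log units; beyond the scatter) is large. Going by the values given here, compound 2 therefore stands at the only number among the values shown; the other entry is the limit (the limit of > 100000 nM in this assay, at which 1 of the 2 values shown sits).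

Compound 3, `COC(=O)c1nc(-c2ccsc2)n(-c2ccc(F)cc2)n1`, has not yet been measured in this assay. It differs from compound 2 by thiophen-3-yl in place of cyclopentyl on an aromatic carbon. Among the compounds with values here, the single measured step concerns the same place, where a five-membered ring of carbon replaced isopropyl and gave an at least 10-fold lower number from compound 1 to compound 2 (1.01 log units; beyond the scatter). Within the data shown here, no measured step sets a five-membered ring of carbon against a five-membered aromatic ring with a sulfur at this place. Since compound 3 keeps a five-membered ring of the same size there, the step expected in this assay is a 1.2-fold lower number from compound 2 to compound 3 (0.08 log units; within the scatter), not beyond the scatter. Compound 3 is thus expected to give 8000 nM, within a range from 2500 nM to 30000 nM.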

Compound 3, concentration for 50% growth inhibition: 54000 nM
Compound 3: the middle estimate sits 6.8-fold (0.83 log units) below what was measured, and the stated range ends below it.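

In this assay ring size alone does not settle this position: thiophen-3-yl in place of cyclopentyl, with the same count of heavy atoms, gives a 5.7-fold higher number from compound 2 to compound 3 (0.75 log units; beyond the scatter) and so separates two five-membered rings on the aromatic carbon between two ring nitrogen atoms. Thiophen-3-yl in place of isopropyl gives an at least 1.8-fold lower number from compound 1 to compound 3 (0.26 log units; that floor lies within the scatter) and so, with that floor inside the scatter, only cyclopentyl is shown to stand clearly apart from isopropyl here. The entry for compound 1 is a limit of the assay and not a number: the limit of > 100000 nM in this assay, at which 1 of the 3 values shown sits.

The compounds shown leave open whether the sulfur or the aromatic ring accounts for the step, and how a cyclohexyl ring or a phenyl ring would fare at this position. They also leave open what a carboxylic acid in place of the methoxycarbonyl group would do.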